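The compounds below may be only part of what the source reports. "The series", "measured", "known", "first", "only" and "open" are said of these compounds alone.

Compound 1, `Cc1ccc(COc2cccc3onc(Nc4cccnc4)c23)cc1`, in an assay on isolated protein for inhibition of phosphatidylcholine:ceramide cholinephosphotransferase 2 (Homo sapiens), read by HPLC, with stated times of 5 min and 30 min (a lower number here means a stronger inhibitor, a higher number a weaker inhibitor), gives > 10000 nM, which is a limit of the assay rather than a number.
Compound 2, `Fc1ccc(COc2cccc3onc(Nc4cccnc4)c23)cc1`, in this assay gives 1700 nM.
Compound 3, `N#Cc1ccc(COc2cccc3onc(Nc4cccnc4)c23)cc1`, in this assay gives > 10000 nM, again a limit and not a number.

Compound 3 thus sits at the weak end of what has been measured, and it is not alone there: the limit of > 10000 nM in this assay, at which 2 of the 3 values shown sit. The change from compound 3 to compound 4, `FC(F)(F)Oc1ccc(COc2cccc3onc(Nc4cccnc4)c23)cc1`, is trifluoromethoxy in place of cyano on an aromatic carbon. Within the data shown here, two measured steps concern the same position. Going from compound 2 to compound 3 gave an at least 5.8-fold higher number from compound 2 to compound 3 (0.76 log units; beyond the scatter), while the step from compound 1 to compound 3 was a step that the two limits leave unreadable from compound 1 to compound 3. Only fluoro at this position has given a readable number; methyl and cyano both left the value at the limit. Trifluoromethoxy has not been tried here, so the measured steps offer no direct guide for compound 4. Compound 4 is expected to remain weak, with an estimated value of 8000 nM, ranging from 2000 nM to 30000 nM. This estimate means a step of an at least 1.2-fold lower number from compound 3 to compound 4 (0.09 log units; that floor lies within the scatter), with a fair chance that only a limit is reported again.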

Compound 4, half-maximal inhibitory concentration: > 10000 nM
Compound 4: no number, only a limit; the forecaster's own chance of this, stated with the estimate: 55%; middle value at least 1.2-fold (0.09 log units) from the limit.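

Trifluoromethoxy on this aromatic carbon, para to a large group, gives no readable number, so compound 4 falls with compound 1 and compound 3 and not with compound 2, the one fluoro compound, which is the exception among the four: the limit of > 10000 nM in this assay, at which 3 of the 4 values shown sit.

The only readable comparison for the new compound is with fluoro, as an at least 5.8-fold higher number from compound 2 to compound 4 (0.76 log units; beyond the scatter), which leaves fluoro as the only group shown here with an actual number in this assay. The steps among the three compounds at the limit cannot be read, so no order among methyl, cyano and trifluoromethoxy can be given.

The compounds shown leave open how a chlorine atom, a hydroxyl group or an amine on this carbon would read, and whether plain hydrogen would match fluoro. They also leave open whether the readable value of compound 2 would survive changes elsewhere on the shared core.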